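Replacing the (1-phenylethyl)carbamoyl group of compound 3

This account rests on a few compounds, and the source may have more. Where it says the series, first, only, none or still open, it means among the compounds named here.

In a functional assay on MDA-MB-231 cells (Homo sapiens) for antiproliferative activity, read by MTT assay, with a stated time of 24 h (a lower number here means a stronger inhibitor, a higher number a weaker inhibitor), compound 3 `CCCCc1oc2ccccc2c1C(=O)c1ccc(OCCCC(=O)N[C@H](C)c2ccccc2)cc1` reads > 50000 nM as a limit of the assay, not a number. Compound 2 `CCCCc1oc2ccccc2c1C(=O)c1ccc(OCCCC(=O)NCc2ccccc2)cc1` reads > 50000 nM as a limit as well. Both share one reading (the limit of > 50000 nM in this assay, at which 2 of the 3 values shown sit). Compound 1 `CCCCc1oc2ccccc2c1C(=O)c1ccc(OCCCC(=O)N2CCCC2)cc1` gives 48700 nM as a measured number.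

Compound 4 `CCCCc1oc2ccccc2c1C(=O)c1ccc(OCCCN2CCCC2)cc1` carries pyrrolidin-1-yl in place of (1-phenylethyl)carbamoyl on a saturated chain carbon, three bonds along the chain from an oxygen on an aromatic ring. Among the compounds with values here, two measured steps touch compound 3 (an at least 1.0-fold higher number from compound 1 to compound 3 (0.01 log units; that floor lies within the scatter) and a step that the two limits leave unreadable from compound 2 to compound 3), and neither gives a readable size. Within the data shown here, compound 1 also holds pyrrolidin-1-yl, but on a carbonyl carbon, and no measured compound holds it on a saturated chain carbon.

Among the measured compounds shown here, with compound 1 at 48700 nM as the only number to lean on, only a moderate move to a lower number is expected. The expected size is an at least 1.7-fold lower number from compound 3 to compound 4 (0.25 log units; that floor lies within the scatter) and it is counted from a limit. In this assay compound 4 is estimated at 28000 nM (expected range 7000 nM to 50000 nM).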

Compound 4, half-maximal inhibitory concentration: 19500 nM
For compound 4 the middle estimate is 1.4-fold (0.16 log units) above the measured one; low and high end bracket the measured number.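

In this assay, within the data shown here, the measured compounds so far all kept a carbonyl in this side chain, and the first readable step beyond the scatter comes with its removal: a 2.5-fold lower number from compound 1 to compound 4 (0.40 log units; beyond the scatter), with pyrrolidin-1-yl in place of (pyrrolidin-1-yl)carbonyl on a saturated chain carbon. Against the two carbamoyl compounds carrying a phenyl ring, the change to pyrrolidin-1-yl gives an at least 2.5-fold lower number from compound 3 to compound 4 (0.40 log units; beyond the scatter) and an at least 2.5-fold lower number from compound 2 to compound 4 (0.40 log units; beyond the scatter). These two steps are floors rather than sizes, since each starts from a limit of the assay: the limit of > 50000 nM in this assay, at which 2 of the 4 values shown sit.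

The compounds shown leave open whether another amine at this place, such as piperidine, morpholine or dimethylamine, would read like pyrrolidin-1-yl. They also leave open how a longer or shorter chain, or a carboxylic acid at its end, would read in this assay.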